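Oxan-4-yl for phenyl: solubility already at the limit

A few compounds are considered here, and "the series" means these few. Any claim that something is new, unique, unknown or untested is made for them only; others in the source may bear on it.

Compound 1 `Cc1cc(N(C)C)nc(NCc2ccccc2)n1` carries a phenyl on a saturated chain carbon bound to a nitrogen on an aromatic ring of the shared core. In a physicochemical assay for solubility, read by nephelometry, measured as kinetic solubility (a higher number here means a more soluble compound, a lower number a less soluble compound), compound 1 gives > 250000 nM, which is a limit of the assay rather than a number. Compound 2 `Cc1cc(N(C)C)nc(N[C@H](C)c2ccccc2)n1` gives > 250000 nM in this assay, again a limit. Compound 3 `Cc1cc(N(C)C)nc(NCc2ccc(Cl)cc2)n1` gives > 250000 nM, also a limit. Because all three sit at the limit of > 250000 nM in this assay, at which 3 of the 3 values shown sit, the steps a step that the two limits leave unreadable from compound 1 to compound 2 and a step that the two limits leave unreadable from compound 1 to compound 3 cannot be read. Compound 4 `Cc1cc(N(C)C)nc(NCC2CCOCC2)n1` is the change (oxan-4-yl in place of phenyl on a saturated chain carbon bound to a nitrogen on an aromatic ring). Among the compounds with values here, no measured step bears on this swap, and none has a readable size. The expected step that the limit leaves unreadable from compound 1 to compound 4 is no change beyond the scatter. Compound 4 is therefore estimated at 300000 nM, between 150000 nM and 600000 nM.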

Compound 4, solubility: > 250000 nM
Compound 4: no number, only a limit; the forecaster's own chance of this, stated with the estimate: 85%; the middle value is on the limit's open side.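

Within the data shown here, compound 1 and compound 4 both stop at a limit of the assay rather than a number, so no step between them can be read: the limit of > 250000 nM in this assay, at which 4 of the 4 values shown sit. As far as these compounds go, how far any of the four compounds lies past that limit in this assay stays open.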